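The compounds below may be only part of what the source reports. "The series", "measured", "known", "first", "only" and "open" are said of these compounds alone.

Values in a functional assay on A-431 cells (Homo sapiens) for cytotoxicity, read by MTT assay, with a stated time of 48 h (on this read-out lower numbers stand for stronger inhibition and higher numbers for weaker inhibition), so far:
- compound 1 `C=CC(C)(O)CC[C@@H]1C(=C)CC[C@H](Br)[C@@]1(C)CCC(Br)C(C)(C)O`: > 100000 nM; > 100000 nM (2 entries)
- compound 2 `C=CC(C)(O)CC[C@@H]1C(=C)CC[C@H](Br)[C@@]1(C)CCC(OC)C(C)(C)O`: > 100000 nM
- compound 3 `C=CC(C)(O)CC[C@@H]1C(=C)CC[C@H](Br)[C@@]1(C)CCC1OC1(C)C`: > 100000 nM

Each of these values is a limit of the assay, not a number. Compound 3 has only the limit > 100000 nM and no exact value of its own. Compound 4 `C=CC(C)(O)CC[C@@H]1C(=C)CC[C@H](Br)[C@@]1(C)CCC(=O)C(C)C` follows from isopropylcarbonyl in place of 3,3-dimethyloxiran-2-yl on a saturated chain carbon, two bonds along the chain from a saturated ring carbon. In words, isopropylcarbonyl takes the place of 3,3-dimethyloxiran-2-yl, and the two compounds have the same atoms, joined differently. Within the data shown here, the one measured step at this place is a step that the two limits leave unreadable from compound 2 to compound 3, so it gives no size to build on. The remaining guide is the limit of > 100000 nM in this assay, at which 2 of the 3 values shown sit. No shift beyond the usual scatter is therefore expected in either direction, and the expected step is a number no higher from compound 3 to compound 4 (the limit leaves the size open). For compound 4 the estimated value is 100000 nM, with an expected range from 50000 nM to 200000 nM.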

Compound 4, half-maximal inhibitory concentration: > 100000 nM
Compound 4: only a limit was reported; the forecaster's own chance of this, stated with the estimate: 85%; the middle value lies on the limit itself.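

Among these compounds, compound 4 also ends at a limit and not a number, so no step to it from compound 2 or compound 3 can be read, because the values share one limit: the limit of > 100000 nM in this assay, at which 3 of the 4 values shown sit. The compounds shown leave open how strongly, if at all, any of them acts on these cells.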